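A few compounds are considered here, and "the series" means these few. Any claim that something is new, unique, unknown or untested is made for them only; others in the source may bear on it.

In an ADME assay on BJ cells (Homo sapiens) for cytotoxicity, with a stated time of 72 h (on this read-out lower numbers stand for an effect already at smaller amounts and higher numbers for an effect only at larger amounts of compound), three compounds sharing one core have been measured so far. Compound 1 `CCc1ccc(-c2nc3c(c(C)nn3-c3ccccc3)c(-c3ccccc3O)c2C#N)cc1` gives > 20000 nM, which is a limit and not a number. Compound 3 `Cc1nn(-c2ccccc2)c2nc(-c3ccc4c(c3)CCCC4)c(C#N)c(-c3ccccc3O)c12` gives > 20000 nM, which is likewise a limit, so its position on the scale is known only as that limit. For the measured compounds named here, compound 2 `Cc1ccccc1-c1nc2c(c(C)nn2-c2ccccc2)c(-c2ccccc2O)c1C#N` gives 21000 nM, the only true number among the three.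

Compound 4 `CCc1cccc(-c2nc3c(c(C)nn3-c3ccccc3)c(-c3ccccc3O)c2C#N)c1` differs from compound 3 by one exchange, 3-ethylphenyl in place of 1,2,3,4-tetrahydronaphthalen-6-yl on an aromatic carbon. Going by the values given here, three measured steps bear on this place on the core: a step that the limit leaves unreadable from compound 1 to compound 2, a step that the two limits leave unreadable from compound 1 to compound 3 and a step that the limit leaves unreadable from compound 2 to compound 3. None of them has a readable size. What they do show is the limit of > 20000 nM in this assay, at which 2 of the 3 values shown sit. Among the compounds with values here, the one number, compound 2 at 21000 nM, belongs to the same high range, so no exchange at this place has yet given a low value.

The step expected is therefore a step that the limit leaves unreadable from compound 3 to compound 4, with no size beyond the scatter in either direction. For compound 4 the estimate is 22000 nM, with an expected range from 12000 nM to 40000 nM.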

Compound 4, half-maximal effective concentration in the BJ assay: > 20000 nM
Compound 4: no number, only a limit (the forecaster's own chance of this, stated with the estimate: 65%); the middle value lies beyond the limit too.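

In the BJ assay compound 4 gives > 20000 nM as well, which is a limit and not a number. No step from compound 1, compound 2 or compound 3 to compound 4 can therefore be read: the limit of > 20000 nM in the BJ assay, at which 3 of the 4 values shown sit.

The compounds shown leave open how far compound 1, compound 3 and compound 4 lie beyond their limits, and so how these groups rank at this place on the shared core.

In a physicochemical assay for solubility, read by spectrophotometry, in phosphate buffer, with a stated time of 18 h, at pH 7.4 (a lower number here means a less soluble compound, a higher number a more soluble compound), compound 3 gives 13000 nM and compound 4 gives 11000 nM with the two values within the scatter of each other.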